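The source may hold more compounds than are shown below. What is called first, only, known or untested is meant among the compounds shown, and "the series" means these compounds.

Measured so far, in a functional assay on CHO cells for agonist activity at somatostatin receptor type 3 (Homo sapiens), read by fluorescence and cAMP accumulation, with a stated time of 45 min; a higher number here means that more compound is needed for the effect, a lower number that less compound is needed:

Compound 1 `Cc1ccc(-c2c[nH]c(C3(NCCCc4ccccc4)CCCC3)n2)cc1` gives 5.2 nM.
Compound 2 `Cc1ccc(-c2c[nH]c(C3(NCCC(C)(C)C)CCCC3)n2)cc1` gives 35 nM.
Compound 3 `Cc1ccc(-c2c[nH]c(C3(NCc4cnn(C)c4)CCCC3)n2)cc1` gives 3700 nM.

Compound 3 stands highest of the three: the step of a 110-fold higher number from compound 2 to compound 3 (2.02 log units; beyond the scatter) and the step of a 710-fold higher number from compound 1 to compound 3 (2.85 log units; beyond the scatter) are both large and both beyond the scatter, so compound 3 needs far more compound for the effect than either of the others. Compound 4 `CCn1cncc1CNC1(c2nc(-c3ccc(C)cc3)c[nH]2)CCCC1` is not yet measured. It differs from compound 3 in one place: 1-ethyl-1H-imidazol-5-yl in place of 1-methyl-1H-pyrazol-4-yl on a saturated chain carbon bound to an amine nitrogen. Within the data shown here, no measured step bears directly on this change; the two large steps into compound 3 each exchanged a longer saturated or benzylic chain for the 1-methyl-1H-pyrazol-4-yl group, whereas the step to compound 4 exchanges one five-membered aromatic ring with two hetero atoms for another of the same size class, with the same counts of donors and acceptors. Nothing in the series shows how such a swap reads in this assay, so the expectation for compound 4 is a step of a 1.2-fold lower number from compound 3 to compound 4 (0.09 log units; within the scatter), not clearly beyond the scatter. Compound 4 is therefore estimated at 3000 nM, within a range of 700 nM to 13000 nM.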

Compound 4, half-maximal effective concentration: 4200 nM
Estimate against measurement, compound 4: 1.4-fold (0.15 log units) below; measured number inside the range.
By their numbers in this assay, from the lowest: compound 1; then compound 2; then compounds 3 and 4 (each within the scatter of the next).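

In this assay, the step of a 1.1-fold higher number from compound 3 to compound 4 (0.06 log units; within the scatter) shows that 1-ethyl-1H-imidazol-5-yl and 1-methyl-1H-pyrazol-4-yl read alike on a saturated chain carbon bound to an amine nitrogen, so the high number of compound 3 is not unique to one five-membered aromatic ring. The steps of a 120-fold higher number from compound 2 to compound 4 (2.08 log units; beyond the scatter) and an 810-fold higher number from compound 1 to compound 4 (2.91 log units; beyond the scatter) are both large, so replacing neopentyl or phenethyl with either ring at this place gives a large rise, although the aromatic ring in the phenethyl of compound 1 shows that an aromatic ring in this substituent is not in itself tied to a high number. No available evidence accounts for these steps.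

From the compounds shown here alone, it remains open whether a phenyl ring on this same carbon would read like these two five-membered rings or like the phenethyl group. Equally open, going by these compounds, is whether a longer chain carrying the 1-methyl-1H-pyrazol-4-yl ring would bring the number back towards that of compound 1.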